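A few compounds are considered here, and "the series" means these few. Any claim that something is new, unique, unknown or untested is made for them only; others in the source may bear on it.

Compound 2 `CCNc1c(C)nc2c(CCc3ccccc3)cccn12` gives 78% in a functional assay on the whole organism with Rattus norvegicus as the target, at a dose of 40 mg/kg by the intraperitoneal route (on this read-out lower numbers stand for less inhibition and higher numbers for more inhibition at the one dose given (going by the name of the read-out)), the highest of the two numbers available. Compound 1 `CC(=O)Nc1c(C)nc2c(CCc3ccccc3)cccn12` gives 40%, and the step of a number 38 percentage points higher from compound 1 to compound 2 (beyond the scatter) shows that changing the group at this site of the shared core moves the read-out strongly. Compound 3 `CSc1c(C)nc2c(CCc3ccccc3)cccn12` carries methylsulfanyl in place of ethylamino on an aromatic carbon. Among the compounds with values here, no measured step covers this exact change, so the one step available only suggests that this site is sensitive. Compound 3 is therefore expected to fall, with wide uncertainty, at 55%, between 25% and 85%, a step of a number 23 percentage points lower from compound 2 to compound 3 (beyond the scatter).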

Compound 3, a percentage reported as inhibition, in the whole organism at one dose (the size of the read-out at that dose, not a potency): 28%
The estimate for compound 3 lay 27 percentage points above the measured number, within the range that was stated.
By their numbers in this assay, from the lowest: compound 3; then compound 1; then compound 2.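

In this assay, this site also responds when a sulfur group replaces a nitrogen group: methylsulfanyl in place of ethylamino brings a number 50 percentage points lower from compound 2 to compound 3 (beyond the scatter), a large drop. Methylsulfanyl in place of acetamido brings a number 12 percentage points lower from compound 1 to compound 3 (beyond the scatter), a modest drop, so both nitrogen-linked groups read higher than methylsulfanyl. Nothing available explains these differences. Still open, from the compounds shown here alone, is whether the drop follows the sulfur or the smaller group, since methylsulfanyl differs from ethylamino in both. Methylamino or ethylsulfanyl would separate the two.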